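Swapping cyclohexyl for pyrrolidin-1-yl on the carbonyl

A few compounds are considered here, and "the series" means these few. Any claim that something is new, unique, unknown or untested is made for them only; others in the source may bear on it.

Compound 1 `O=C(C1CCCCC1)N1CCc2nc(C#Cc3ccccc3)sc2C1`: 167 nM
Compound 2 `O=S(=O)(C1CCCCC1)N1CCc2nc(C#Cc3ccccc3)sc2C1`: > 10000 nM
Compound 3 `O=S(=O)(C1CCCCC1)N1Cc2nc(C#Cc3ccccc3)sc2C1`: 150 nM

Of the compounds shown here, three sharing the same core have been tested in an assay on HEK293 cells for positive allosteric modulation of metabotropic glutamate receptor 5 (Homo sapiens), read by FLIPR, with a stated time of 1 h; a higher number here means that more compound is needed for the effect, a lower number that less compound is needed. Compound 1 gives 167 nM, the higher of the two numbers that were actually read. Compound 3 sits nearest with 150 nM, and the gap between the two is within the scatter, so they cannot be told apart. Compound 2 is a different case: its result is a limit of the assay, (the limit of > 10000 nM in this assay, at which 1 of the 3 values shown sits), not a number.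

Compound 4 `O=C(N1CCCC1)N1CCc2nc(C#Cc3ccccc3)sc2C1` has not yet been measured. It differs from compound 1 in one place: pyrrolidin-1-yl in place of cyclohexyl on a carbonyl carbon. For the measured compounds named here, no measured pair shows this change, so nothing in the data fixes its size. The expectation is a small shift towards a higher number in this assay for compound 4, though one that may well stay within the scatter.

The estimated value for compound 4 is 350 nM, with a range from 120 nM to 1500 nM. The expected step of a 2.1-fold higher number from compound 1 to compound 4 (0.32 log units; beyond the scatter) is small.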

Compound 4, half-maximal effective concentration: 9.8 nM
For compound 4 the middle estimate is 36-fold (1.55 log units) above the measured one, outside the stated range (below it).
By their numbers in this assay, from the lowest: compound 4; then compounds 3 and 1 (each within the scatter of the next). At a limit, above all of these: compound 2.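

Putting pyrrolidin-1-yl in place of cyclohexyl on a carbonyl carbon gives a 17-fold lower number from compound 1 to compound 4 (1.23 log units; beyond the scatter) in this assay, which shows that the group at this position can strongly change how much compound is needed for the effect. The size of this step stands out. The two groups look much alike on paper: each is a single non-aromatic ring with no hydrogen-bond donors or acceptors and no net charge, and they differ only in that a five-membered ring with one nitrogen replaces a six-membered ring of carbon only. Nothing measured here explains why this swap has so large an effect.

This single pair changes two things at once, ring size and the atom joined to the carbonyl, so it cannot show which of them matters. Cyclopentyl, which has the smaller ring but no nitrogen, and piperidin-1-yl, which has the nitrogen in a six-membered ring, would each change only one of these, and how either would behave on the shared core remains open.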